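A few compounds are considered here, and "the series" means these few. Any claim that something is new, unique, unknown or untested is made for them only; others in the source may bear on it.

Measured compounds:
compound 1 `COc1cccc(-n2cc3nc(-c4cccnc4C)n(C[C@H]4CCCN(Cc5ccco5)C4)c(=O)c3n2)c1`: 2.7 nM
compound 2 `COc1cccc(-n2cc3nc(-c4cccnc4C)n(C[C@H]4CCCN(CC5CCC5)C4)c(=O)c3n2)c1`: 1.6 nM
compound 3 `COc1cccc(-n2cc3nc(-c4cccnc4C)n(C[C@H]4CCCN(CC(C)C)C4)c(=O)c3n2)c1`: 5.7 nM

In an assay on HEK293 cells for displacement of a labelled ligand from growth hormone secretagogue receptor type 1 (Homo sapiens), with a stated time of 60 min (a higher number here means a weaker inhibitor, a lower number a stronger inhibitor), compound 3 stands at the highest number of the three. The steps of a 2.1-fold higher number from compound 1 to compound 3 (0.32 log units; beyond the scatter) and a 3.6-fold higher number from compound 2 to compound 3 (0.55 log units; beyond the scatter) are both modest and beyond the scatter, whereas a 1.7-fold lower number from compound 1 to compound 2 (0.23 log units; within the scatter) lies within it. Compound 4 `CCO[C@H](C)CN1CCC[C@H](Cn2c(-c3cccnc3C)nc3cn(-c4cccc(OC)c4)nc3c2=O)C1` carries 1-ethoxyethyl in place of isopropyl on a saturated chain carbon bound to an amine nitrogen in a ring. All three measured steps concern the same position, and in each case the isopropyl group stands at the higher number. Going by the values given here, no measured compound carries a chain with an acceptor at this position, so the direction of the new change is uncertain; by the precedent of compound 1 and compound 2, a modest lower number is expected, a 1.9-fold lower number from compound 3 to compound 4 (0.28 log units; within the scatter). Compound 4 is therefore estimated at 3 nM, with a range of 1.2 nM to 8 nM.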

Compound 4, half-maximal inhibitory concentration: 40 nM
Compound 4: middle estimate off by 13-fold (1.12 log units), on the low side, and the stated range ends below it.
By their numbers in this assay, from the lowest: compounds 2 and 1 (each within the scatter of the next); then compound 3; then compound 4.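

In this assay, 1-ethoxyethyl in place of isopropyl on a saturated chain carbon bound to an amine nitrogen in a ring gives (a 7.0-fold higher number from compound 3 to compound 4 (0.85 log units; beyond the scatter)), and the gaps from the other two groups are larger (a 15-fold higher number from compound 1 to compound 4 (1.17 log units; beyond the scatter); a 25-fold higher number from compound 2 to compound 4 (1.40 log units; beyond the scatter)). This position therefore does not accept every group, and the open-chain ether stands well apart from furan-2-yl, cyclobutyl and isopropyl. No measured evidence available here explains the change.

On these data alone, whether the ether oxygen or the longer chain sets this step remains open. An all-carbon chain of the same length and the opposite stereoisomer of 1-ethoxyethyl would separate these readings.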